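Replacing the bromo with methoxy on the pendant ring

This account rests on a few compounds, and the source may have more. Where it says the series, first, only, none or still open, it means among the compounds named here.

Compound 1, `O=c1c2ccccc2[se]n1-c1nnc(-c2ccc(Br)cc2)s1`: 39100 nM
Compound 2, `O=c1c2ccccc2[se]n1-c1nnc(-c2ccccc2Br)s1`: 12700 nM

For the measured compounds named here, in a functional assay on A549 cells (Homo sapiens) for antiproliferative activity, read by CCK-8 assay, with a stated time of 48 h (on this read-out lower numbers stand for stronger inhibition and higher numbers for weaker inhibition), compound 2 holds the lower of the two numbers; its only neighbour is compound 1, and the step of a 3.1-fold lower number from compound 1 to compound 2 (0.49 log units; beyond the scatter) is modest yet beyond the scatter. Compound 3, `COc1ccccc1-c1nnc(-n2[se]c3ccccc3c2=O)s1`, differs from compound 2 by methoxy in place of bromo on an aromatic carbon. Going by the values given here, no measured step exchanges one group for another at this spot; the single step measured so far swapped 4-bromophenyl for 2-bromophenyl and bears only loosely on it. With nothing firmer to lean on, no shift beyond the scatter in this assay is foreseen. Compound 3 is therefore expected near 15000 nM, within 5000 nM to 50000 nM. The expected step is a 1.2-fold higher number from compound 2 to compound 3 (0.07 log units; within the scatter).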

Compound 3, half-maximal inhibitory concentration: 3120 nM
For compound 3 the middle estimate is 4.8-fold (0.68 log units) above the measured one; the whole stated range lies above it.
By their numbers in this assay, from the lowest: compound 3; then compound 2; then compound 1.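

Methoxy in place of bromo gives a 4.1-fold lower number from compound 2 to compound 3 (0.61 log units; beyond the scatter) in this assay on the same aromatic carbon, so this spot responds to which group sits on it, not only to where a bromo is placed. The change also brings in a hydrogen-bond acceptor that the bromo lacks, but no measurement here explains the lower number. Still open, from the compounds shown here alone, is how an amine, a carboxylic acid or a longer chain such as ethoxy would fare on this carbon, and whether methoxy would give a similar step in the 4-substituted series of compound 1.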